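The compounds below may be only part of what the source reports. "The series", "measured", "known", "first", "only" and "open" are said of these compounds alone.

The measured compounds are: compound 1, `CCCCCCNC(=O)/C=C/c1ccccc1`, giving 82% in a functional assay on the whole organism for inhibition, with Brassica rapa subsp. chinensis as the target, with a stated time of 3 days, tested at 100 ppm; a lower number here means less inhibition of growth, a higher number more inhibition of growth at the concentration tested; compound 2, `CCCCCCCCCCNC(=O)/C=C/c1ccccc1`, giving 15%; and compound 3, `COC(=O)/C=C/c1ccc(C(C)C)cc1`, giving 21%.

Compound 1 and compound 2 share a core and differ in one place, (butyl in place of hydrogen on a saturated chain carbon, six bonds along the chain from an amide-type nitrogen). That change produced a number 67 percentage points lower from compound 1 to compound 2 (beyond the scatter). How the core of compound 3 differs from that of compound 1 is not broken down here. The values of compound 3 and compound 2 lie within the scatter of each other, so nothing separates them.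

Compound 4, `CCCCCOC(=O)/C=C/c1ccc(C(C)C)cc1`, has not yet been measured. It differs from compound 3 by butyl in place of hydrogen on a saturated chain carbon bound to an oxygen next to a carbonyl group. This is the same kind of change as from compound 1 to compound 2, butyl in place of hydrogen on a saturated chain carbon, but the place is not the same: in compound 1 that carbon is six bonds along the chain from an amide-type nitrogen, whereas in compound 3 it is bound to an oxygen next to a carbonyl group.

Since compound 3 already gives 21%, a step like the earlier one has little room. The step from compound 3 to compound 4 is expected to be a number 11 percentage points lower from compound 3 to compound 4 (beyond the scatter). Compound 4 is estimated at 10%, between 0% and 35%.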

Compound 4, percent growth inhibition at one concentration: 0%
Compound 4: middle estimate off by 10 percentage points, on the high side; the range from low to high includes it.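

In this assay, butyl in place of hydrogen on the saturated chain carbon bound to an oxygen next to a carbonyl group gave a number 21 percentage points lower from compound 3 to compound 4 (beyond the scatter), so this change lowered the number on both cores, though by different amounts: the same change on two cores in this assay, a number 67 percentage points lower (beyond the scatter) from compound 1 to compound 2 and a number 21 percentage points lower (beyond the scatter) from compound 3 to compound 4, 46 percentage points apart, beyond the scatter of two such steps. The smaller step has a low starting point, with compound 3 at 21% and compound 4 at 0%, so its size says little about how far the change could lower the number on a core that starts higher. The two pairs show a shared direction on these two cores only, and they do not show whether the gap in size comes from the core, from the place of the change or from the starting value.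

On these data alone, it remains open how an intermediate chain, such as octyl on the amide nitrogen or propyl in place of the methyl of compound 3, would read in this assay. Also open, as far as these compounds go, is how a carboxylic acid in place of the methoxy group of compound 3 would compare.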